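Capping an Aromatic Amine and Expected Cell Tolerance

The compounds below may be only part of what the source reports. "The series", "measured", "known", "first", "only" and "open" are said of these compounds alone.

Of the compounds shown here, two that share one core have so far been measured in an ADME assay on MT4 cells (Homo sapiens) for cytotoxicity, read by MTT assay, with a stated time of 4 days; a higher number here means that more compound is tolerated, a lower number that less compound is tolerated. Compound 1, `Cc1ccc(-c2c(C)c(-c3ccc(C)c(C)c3)c(C(OC(C)(C)C)C(=O)O)c(C)c2N)cc1C`, gives 12000 nM. Compound 2, `Cc1ccc(-c2c(C)c(-c3ccc4c(c3)CCCO4)c(C(OC(C)(C)C)C(=O)O)c(C)c2NS(C)(=O)=O)cc1C`, gives 28000 nM in this assay. Of these two numbers, compound 1 gives the lower one, and the gap to compound 2 lies beyond the usual scatter; since compound 2 differs from compound 1 in more than one place, only the two values themselves can be set side by side. Compound 3, `CCC(=O)Nc1c(C)c(C(OC(C)(C)C)C(=O)O)c(-c2ccc(C)c(C)c2)c(C)c1-c1ccc(C)c(C)c1`, has not yet been measured. It differs from compound 1 in a single place: propanoyl in place of hydrogen on a nitrogen on an aromatic ring. For the measured compounds named here, no step between measured compounds that differ in one place is available, so the size of this change can only be projected. The step from compound 1 to compound 3 is expected to be modest and upward, if beyond the scatter at all: a 1.5-fold higher number from compound 1 to compound 3 (0.18 log units; within the scatter). Compound 3 is accordingly estimated at 18000 nM, with a range from 8000 nM to 40000 nM.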

Compound 3, half-maximal cytotoxic concentration: 15000 nM
The estimate for compound 3 lay 1.2-fold (0.08 log units) above the measured number, within the range that was stated.
By their numbers in this assay, from the lowest: compounds 1, 3 and 2 (each within the scatter of the next, the first and the last beyond it).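

For the compounds shown here, compound 3 gives the first step in this set that changes one place only: with propanoyl in place of hydrogen on a nitrogen on an aromatic ring, this assay shows a 1.3-fold higher number from compound 1 to compound 3 (0.10 log units; within the scatter), a step within the scatter. On the core of compound 1, then, the change from amino to propanoylamino does not produce a difference in tolerated concentration that this assay can separate from repeat-to-repeat variation. No measurement is available that would explain this result.

This single step leaves open whether other groups on the same nitrogen, such as a longer chain like octanoyl or a chain ending in a carboxylic acid or an amine, would also stay within the scatter. It also cannot show whether propanoyl would behave in the same way on a different core.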